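The compounds below may be only part of what the source reports. "The series", "measured", "known", "first", "only" and "open" are said of these compounds alone.

Compound 1 `CCCOC(=O)C1=C(C)NC(=O)NC1c1ccoc1` and compound 2 `CC1=C(C(=O)OC(C)(C)C)C(c2ccoc2)NC(=O)N1` share one core and differ only in the ester. In an assay on membranes from HeLa cells for displacement of a labelled ligand from adenosine receptor A3 (Homo sapiens), read by scintillation counting, with a stated time of 180 min, tested at 1 uM (a lower number here means less inhibition, a higher number more inhibition at the concentration tested (going by the name of the read-out)), compound 1 gives 11%, and compound 2 gives 2%; the step of a number 9 percentage points lower from compound 1 to compound 2 (within the scatter) lies within the scatter, so the two numbers cannot be told apart, and compound 1 stands at a low level of inhibition with no measured partner set apart from it.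

Compound 3 `CCCOC(=O)C1=C(C)NC(=O)NC1c1ccsc1` keeps the propyl ester of compound 1 and carries thiophen-3-yl in place of furan-3-yl on a saturated ring carbon. Within the data shown here, no measured step covers this change: the only step concerns the ester and was within the scatter. With both measured numbers low and close, no step beyond the scatter is expected in this assay for compound 3 in either direction. Compound 3 is therefore estimated at 12%, in the range 0% to 30%. The expected step of a number 1 percentage points higher from compound 1 to compound 3 (within the scatter) is small.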

Compound 3, a percentage reported as inhibition, at one concentration (the size of the read-out at that concentration, not a potency): 6%
For compound 3 the middle estimate is 6 percentage points above the measured one; low and high end bracket the measured number.
By their numbers in this assay, from the lowest: compounds 2, 3 and 1 (each within the scatter of the next).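

Among these compounds, on the saturated ring carbon, the exchange of furan-3-yl for thiophen-3-yl gives the first reading at this position in this assay, with the propyl ester held constant: a number 5 percentage points lower from compound 1 to compound 3 (within the scatter). Read beside the ester step, a number 9 percentage points lower from compound 1 to compound 2 (within the scatter), this means that changes at two separate places on the shared core have now each stayed inside the scatter, so neither place is yet set apart by these numbers. No available evidence bears on the reason for this result.

Going by these compounds, whether a different kind of group on this saturated ring carbon, such as a phenyl ring or a chain carrying an amine, would give a step beyond the scatter remains open. So does the effect of a longer chain on the ester oxygen.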